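Working notes: swapping one aryl group at compound 3

This account rests on a few compounds, and the source may have more. Where it says the series, first, only, none or still open, it means among the compounds named here.

Measured so far in a functional assay on THP-1 cells (Homo sapiens) for cytotoxicity, read by MTT assay, with a stated time of 24 h; a higher number here means a weaker inhibitor, a lower number a stronger inhibitor
Compound 1 `COc1cc(/C=C2\CN(C)C/C(=C\c3ccccc3F)C2=O)cc(OC)c1OC` gives 640 nM
Compound 2 `COc1cc(/C=C2\CN(C)C/C(=C\c3ccc(F)cc3)C2=O)cc(OC)c1` gives 5040 nM
Compound 3 `COc1cc(/C=C2\CN(C)C/C(=C\c3cc(OC)c(OC)c(OC)c3)C2=O)cc(OC)c1` gives 720 nM

Compound 3 is level with compound 1 within the scatter, and both stand well under compound 2. Compound 4 `COc1cc(/C=C2\CN(C)C/C(=C\c3ccc(F)cc3)C2=O)cc(OC)c1OC` has 4-fluorophenyl in place of 3,5-dimethoxyphenyl on a double-bonded chain carbon bound to a double-bonded ring carbon. The closest measured exchange at this place, a 1.1-fold higher number from compound 1 to compound 3 (0.05 log units; within the scatter), stayed within the scatter and suggests little change. Within the data shown here, compound 2, the only measured compound with 4-fluorophenyl, gives 5040 nM and tilts the expectation towards a higher number. In this assay the expected step is small and upward, not beyond the scatter (a 1.4-fold higher number from compound 3 to compound 4 (0.14 log units; within the scatter)). The estimate for compound 4 is 1000 nM, with an expected range of 400 nM to 2800 nM.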

Compound 4, half-maximal inhibitory concentration: 6130 nM
For compound 4 the middle estimate is 6.1-fold (0.79 log units) below the measured one; the measured number lies above the stated range.
By their numbers in this assay, from the lowest: compounds 1 and 3 (each within the scatter of the next); then compounds 2 and 4 (each within the scatter of the next).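

In this assay the aryl group at this place sets the number: 4-fluorophenyl in place of 3,5-dimethoxyphenyl gives an 8.5-fold higher number from compound 3 to compound 4 (0.93 log units; beyond the scatter) and the exchange is not neutral. Moving the fluorine also counts, since 4-fluorophenyl in place of 2-fluorophenyl gives a 9.6-fold higher number from compound 1 to compound 4 (0.98 log units; beyond the scatter) at the same place. With 4-fluorophenyl held fixed, methoxy in place of hydrogen on an aromatic carbon gives only a 1.2-fold higher number from compound 2 to compound 4 (0.09 log units; within the scatter) and so does not offset this exchange.

As far as these compounds go, whether an amine or a carboxylic acid on the same carbon would stay level with compound 1 remains open. No supporting data explain the size of these steps.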